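The compounds below may be only part of what the source reports. "The series", "measured", "known", "first", "only" and "open" are said of these compounds alone.

In an ADME assay on MDBK cells (Bos taurus) for cytotoxicity (on this read-out lower numbers stand for higher toxicity in this test and higher numbers for lower toxicity in this test), compound 1 `Brc1ccccc1Cn1ccc2nc(-c3ccccc3)nc-2c1` gives > 100000 nM, which is a limit of the assay. Within the data shown here, compound 2 `Clc1ccc(Cn2ccc3nc(-c4ccccc4)nc-3c2)cc1Cl` gives 71000 nM, the only actual number so far. Compound 3 `C(=C/c1ccccc1)\Cn1ccc2nc(-c3ccccc3)nc-2c1` has 2-phenylethenyl in place of 3,4-dichlorophenyl on a saturated chain carbon bound to an aromatic nitrogen. Among the measured compounds shown here, the one measured step bearing on this change, an at least 1.4-fold lower number from compound 1 to compound 2 (0.14 log units; that floor lies within the scatter), swaps the group at the same place and starts from a limit (the limit of > 100000 nM in this assay, at which 1 of the 2 values shown sits). No step beyond the scatter is therefore expected in this assay, and no direction is favoured. The estimated step is a 1.1-fold higher number from compound 2 to compound 3 (0.02 log units; within the scatter). For compound 3 the expected value is 75000 nM, with an estimated range of 35000 nM to 100000 nM.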

Compound 3, half-maximal cytotoxic concentration: 78000 nM
Compound 3: the middle estimate sits 1.0-fold (0.02 log units) below what was measured; the range from low to high includes it.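

In this assay, the step of a 1.1-fold higher number from compound 2 to compound 3 (0.04 log units; within the scatter) shows that a non-chlorinated group with a double bond outside aromatic rings can take the place of 3,4-dichlorophenyl on a saturated chain carbon bound to an aromatic nitrogen with no change beyond the scatter. Compound 1 stands at a limit of the assay: the limit of > 100000 nM in this assay, at which 1 of the 3 values shown sits. The step read from that limit, an at least 1.2-fold lower number from compound 1 to compound 3 (0.10 log units; that floor lies within the scatter), gives only a floor and separates 2-phenylethenyl from 2-bromophenyl by nothing beyond the scatter. The compounds shown leave open whether any group at this place moves the read-out beyond the scatter, for example an amine or a carboxylic acid.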